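This account rests on a few compounds, and the source may have more. Where it says the series, first, only, none or still open, it means among the compounds named here.

Compound 1 `CN(C)CCNc1nc(-c2ccc(NC(=O)Nc3ccccc3)cc2)nc2ccsc12`, compound 2 `CN(C)CCNc1nc(-c2ccc(NC(=O)Nc3ccccc3F)cc2)nc2ccsc12` and compound 3 `CN(C)CCNc1nc(-c2ccc(NC(=O)Nc3ccccc3Cl)cc2)nc2ccsc12` share one core and differ only at a single aromatic carbon, which carries hydrogen in compound 1, fluoro in compound 2 and chloro in compound 3. In a functional assay on HT-29 cells (Homo sapiens) for cytotoxicity, read by MTT assay, with a stated time of 72 h (a higher number here means a weaker inhibitor, a lower number a stronger inhibitor), compound 1 gives 620 nM, compound 2 gives 510 nM and compound 3 gives 310 nM. The steps of a 2.0-fold lower number from compound 1 to compound 3 (0.30 log units; within the scatter) and a 1.6-fold lower number from compound 2 to compound 3 (0.22 log units; within the scatter) separate compound 3 from the other two, so the three numbers are not truly told apart. Compound 4 `CN(C)CCNc1nc(-c2ccc(NC(=O)Nc3ccc(Cl)cc3Cl)cc2)nc2ccsc12` takes compound 3 one step further: chloro in place of hydrogen on an aromatic carbon. For the measured compounds named here, the only measured steps that bear on adding a chloro are a 2.0-fold lower number from compound 1 to compound 3 (0.30 log units; within the scatter) and a 1.6-fold lower number from compound 2 to compound 3 (0.22 log units; within the scatter), both small. A second chloro is therefore expected to shift the number little, if at all, beyond the scatter. Compound 4 is expected to give about 250 nM, between 100 nM and 650 nM, a step of a 1.2-fold lower number from compound 3 to compound 4 (0.09 log units; within the scatter).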

Compound 4, half-maximal inhibitory concentration: 1320 nM
The estimate for compound 4 lay 5.3-fold (0.72 log units) below the measured number; the measured number lies above the stated range.
By their numbers in this assay, from the lowest: compounds 3, 2 and 1 (each within the scatter of the next); then compound 4.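

In this assay, adding chloro to the 2-chlorophenyl group, on the carbon para to a large group, gives a 4.3-fold higher number from compound 3 to compound 4 (0.63 log units; beyond the scatter), a step beyond the scatter and against the direction of the earlier small differences. The 2,4-dichlorophenyl group also stands apart from the other two aromatic groups, with a 2.6-fold higher number from compound 2 to compound 4 (0.41 log units; beyond the scatter) and a 2.1-fold higher number from compound 1 to compound 4 (0.33 log units; beyond the scatter), so a change at this carbon can move the number clearly. No measurement here gives a reason for this rise. As far as these compounds go, whether the rise is specific to chloro remains open, as a methoxy group or an amine on this same carbon could show. Also open, from the compounds shown here alone, is whether the step depends on the chloro group already present on the ring.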